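From sulfonyl to sulfanyl in a bromophenyl compound

A few compounds are considered here, and "the series" means these few. Any claim that something is new, unique, unknown or untested is made for them only; others in the source may bear on it.

Compound 1 `Cc1ccc(CS(=O)(=O)/C(=C/c2ccccc2OCc2ccccc2)C(=O)c2ccc(Cl)cc2)cc1`: 1000 nM
Compound 2 `O=C(/C(=C\c1ccccc1OCc1ccccc1)S(=O)(=O)c1ccc(F)cc1)c1ccc(Cl)cc1`: 1000 nM
Compound 3 `O=C(/C(=C\c1ccccc1OCc1ccccc1)S(=O)(=O)c1ccc(Br)cc1)c1ccc(Cl)cc1`: 1000 nM

In a functional assay on DU-145 cells (Homo sapiens) for inhibition, read by trypan blue exclusion, with a stated time of 96 h (a higher number here means a weaker inhibitor of growth, a lower number a stronger inhibitor of growth), compound 3 stands level with compounds 1 and 2. Compound 4 `O=C(/C(=C\c1ccccc1OCc1ccccc1)Sc1ccc(Br)cc1)c1ccc(Cl)cc1` has not yet been measured. It differs from compound 3 in one place: (4-bromophenyl)sulfanyl in place of (4-bromophenyl)sulfonyl on a double-bonded chain carbon bound to a carbonyl carbon and a double-bonded chain carbon. The swap of (4-bromophenyl)sulfonyl for (4-bromophenyl)sulfanyl takes place on a double-bonded chain carbon bound to a carbonyl carbon and a double-bonded chain carbon.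

Three measured steps offer only indirect guidance: no change at the digits printed from compound 1 to compound 2 (within the scatter), no change at the digits printed from compound 1 to compound 3 (within the scatter) and no change at the digits printed from compound 2 to compound 3 (within the scatter). Each alters the group on a sulfonyl sulfur, and all three stay within the scatter. Going by these compounds, none replaces the sulfonyl itself, so this change is untested in this assay. The working expectation is therefore no step beyond the scatter, held loosely. The expected step is a 1.5-fold higher number from compound 3 to compound 4 (0.18 log units; within the scatter). For compound 4 the estimated value is 1500 nM, with an expected range from 400 nM to 6000 nM.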

Compound 4, concentration for 50% growth inhibition: 10000 nM
Beside the measured number, compound 4's estimate is 6.7-fold (0.82 log units) below it, outside the stated range (above it).
By their numbers in this assay, from the lowest: compounds 1, 2 and 3 (each within the scatter of the next); then compound 4.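

In this assay the sulfonyl group itself proves to matter at this position: the earlier changes to the group on the sulfonyl sulfur all stayed within the scatter, but (4-bromophenyl)sulfanyl in place of (4-bromophenyl)sulfonyl gives a 10-fold higher number from compound 3 to compound 4 (1.00 log units; beyond the scatter) and so a weaker inhibitor of growth. Compound 4 sits equally far from the other two sulfonyl compounds, with a 10-fold higher number from compound 2 to compound 4 (1.00 log units; beyond the scatter) and a 10-fold higher number from compound 1 to compound 4 (1.00 log units; beyond the scatter) as well, so in these four compounds the sulfonyl compounds stay together and only the sulfanyl compound stands apart. Nothing available here accounts for this step.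

The compounds shown leave open whether a sulfinyl group or an amide on that same carbon would stay level with compound 3 or fall with compound 4. They also leave open whether the sulfanyl swap costs as much with 4-fluorophenyl or 4-methylbenzyl on the sulfur.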